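Cytotoxicity notes on the amide aryl swap in the series

This account rests on a few compounds, and the source may have more. Where it says the series, first, only, none or still open, it means among the compounds named here.

Three compounds of the series have been run in an ADME assay on MT4 cells (Homo sapiens) for cytotoxicity, read by MTT assay, with a stated time of 5 days; on this read-out higher numbers stand for lower toxicity in this test and lower numbers for higher toxicity in this test. For the measured compounds named here, compound 1 `COc1cc2nc(Nc3ccc(C#N)cc3)nc(Nc3c(F)cc(/C=C/C#N)cc3F)c2cc1OC` is the only one with a numerical reading: in this assay compound 1 gives 6400 nM. Compound 2 `COc1cc2nc(SCC(=O)Nc3cc([N+](=O)[O-])ccc3F)nc(Nc3c(Cl)cc(/C=C/C#N)cc3Cl)c2cc1OC` reaches only the limit of the test, and in this assay compound 2 is reported as > 199000 nM. Compound 3 `COc1cc2nc([S+]([O-])CC(=O)Nc3cccc([N+](=O)[O-])c3)nc(Nc3c(Cl)cc(/C=C/C#N)cc3Cl)c2cc1OC` likewise stops at a limit: in this assay compound 3 gives >= 83200 nM. Compound 3 therefore stands at the limit of >= 83200 nM in this assay, at which 1 of the 3 values shown sits. The other limit in the set is the limit of > 199000 nM in this assay, at which 1 of the 3 values shown sits. Going by the values given here, no two measured compounds differ in a single place; no step between measured compounds is available.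

Compound 4 `COc1ccccc1NC(=O)C[S+]([O-])c1nc(Nc2c(Cl)cc(/C=C/C#N)cc2Cl)c2cc(OC)c(OC)cc2n1` has not yet been measured. It differs from compound 3 in one place: 2-methoxyphenyl in place of 3-nitrophenyl on an amide-type nitrogen. The group that changes sits on an amide-type nitrogen whose other neighbour is the carbonyl carbon; cut one bond further out, the same difference reads (3-nitrophenyl)carbamoyl to (2-methoxyphenyl)carbamoyl. With compound 3 already at a limit, the step in this assay is expected to be none beyond the scatter, and the estimated step is a step that the limit leaves unreadable from compound 3 to compound 4. Compound 4 is expected to give 100000 nM, in the range 30000 nM to 300000 nM, most likely again reported as a limit.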

Compound 4, half-maximal cytotoxic concentration: > 204000 nM
Compound 4: no number, only a limit; the forecaster's own chance of this, stated with the estimate: 70%; middle value at least 2.0-fold (0.30 log units) from the limit.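

In this assay compound 4 gives > 204000 nM, which is a limit and not a number. For the compounds shown here, compound 3 also stands at a limit, >= 83200 nM, so no step from compound 3 to compound 4 can be read. The compounds shown leave open what 2-methoxyphenyl in place of 3-nitrophenyl on an amide-type nitrogen does in this assay.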